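The source may hold more compounds than are shown below. What is called first, only, known or untested is meant among the compounds shown, and "the series" means these compounds.

Working notes on the series. Of the compounds shown here, three have been measured in a functional assay on HT-29 cells (Homo sapiens) for inhibition, read by MTT assay, with a stated time of 72 h; a lower number here means a stronger inhibitor of growth, a higher number a weaker inhibitor of growth. Compound 1 `N#C/C(=C\c1ccc(Cl)cc1)C(=O)c1ccc[nH]1` gives 36000 nM in this assay. Compound 2 `N#C/C(=C\c1ccc([N+](=O)[O-])cc1)C(=O)c1c[nH]c2ccccc12` gives 41000 nM in this assay, a value within the scatter of compound 1. Compound 3 `COc1ccc(CNC(=O)/C(C#N)=C/c2ccc[nH]2)cc1` stands apart: in this assay compound 3 returns only a limit, > 50000 nM, so no number is known for it. That limit is the point described in the limit of > 50000 nM in this assay, at which 1 of the 3 values shown sits, and one of the three values shown sits there. For the measured compounds named here, no pair among compounds 1, 2 and 3 differs in one place, so no measured step exists.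

The next compound, compound 4 `COc1ccc(CNC(=O)/C(C#N)=C/c2ccc(C)cc2)cc1`, differs from compound 3 in one place: 4-methylphenyl in place of 1H-pyrrol-2-yl on a double-bonded chain carbon bound to a double-bonded chain carbon. With compound 3 known only as a limit, the direction of the step cannot be read from a measured step; the two numbered values of compounds 1 and 2 both lie near that limit, so no step beyond the scatter is expected, and the step from compound 3 to compound 4 is estimated as an at least 1.1-fold lower number from compound 3 to compound 4 (0.04 log units; that floor lies within the scatter). Compound 4 is expected to give about 45000 nM in this assay, within a range from 20000 nM to 90000 nM, with a fair chance that only a limit is reported again.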

Compound 4, concentration for 50% growth inhibition: 36000 nM
Estimate against measurement, compound 4: 1.3-fold (0.10 log units) above; the range from low to high includes it.
By their numbers in this assay, from the lowest: compounds 1, 4 and 2 (each within the scatter of the next). At a limit, above all of these: compound 3.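

In this assay, for the compounds shown here, this position yields the first step, with 4-methylphenyl in place of 1H-pyrrol-2-yl on a double-bonded chain carbon bound to a double-bonded chain carbon: an at least 1.3-fold lower number from compound 3 to compound 4 (0.14 log units; that floor lies within the scatter). That figure is a floor and not a size, set by the limit returned by compound 3: the limit of > 50000 nM in this assay, at which 1 of the 4 values shown sits. Compound 4 shows that a ring of carbon only at this place gives a number, but not that it improves on 1H-pyrrol-2-yl.

Whether the true step goes beyond the scatter cannot be read while compound 3 stands at a limit. Going by these compounds, it also stays open whether the ring or its methyl carries the change, and what a plain phenyl or a 4-aminophenyl group would give at this place.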